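Estimating Compound 4 From Three Measured Analogues

This account rests on a few compounds, and the source may have more. Where it says the series, first, only, none or still open, it means among the compounds named here.

Compound 1, `O=C(COc1ccc(C(=O)/C=C/c2ccc(Cl)cc2Cl)cc1)N[C@H]1CCOC1=O`: in a functional assay on PC-3 cells (Homo sapiens) for antiproliferative activity, read by MTT assay, with a stated time of 72 h (on this read-out higher numbers stand for weaker inhibition and lower numbers for stronger inhibition), compound 1 gives 8040 nM.
Compound 2, `COc1ccccc1/C=C/C(=O)c1ccc(OCC(=O)N[C@H]2CCOC2=O)cc1`: in this assay compound 2 gives 7240 nM.
Compound 3, `CC(C)(C)c1ccc(/C=C/C(=O)c2ccc(OCC(=O)N[C@H]3CCOC3=O)cc2)cc1`: in this assay compound 3 gives 10600 nM.

Compound 3 carries the highest of the three numbers, but neither gap is meaningful: a 1.3-fold higher number from compound 1 to compound 3 (0.12 log units; within the scatter) and a 1.5-fold higher number from compound 2 to compound 3 (0.17 log units; within the scatter). The shared core is the same in all three; what varies is the aromatic ring attached to the double-bonded chain carbon.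

Compound 4, `O=C(COc1ccc(C(=O)/C=C/c2cccc(Br)c2)cc1)N[C@H]1CCOC1=O`, changes that same ring once more: 3-bromophenyl in place of 4-(tert-butyl)phenyl on a double-bonded chain carbon bound to a double-bonded chain carbon. Every measured step here swaps the ring at this same place, and every one of them stayed within the scatter, including a 1.1-fold lower number from compound 1 to compound 2 (0.05 log units; within the scatter). Three different rings, two of them bearing halogen, give numbers that cannot be told apart, so a fourth ring of this kind is expected to land in the same band rather than move the read-out in either direction.

Compound 4 is therefore expected to give roughly 8000 nM in this assay. Its expected range runs from 4000 nM to 16000 nM. The expected step is a 1.3-fold lower number from compound 3 to compound 4 (0.12 log units; within the scatter), a change not expected to exceed the scatter.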

Compound 4, half-maximal inhibitory concentration: 7890 nM
The estimate for compound 4 lay 1.0-fold (0.01 log units) above the measured number, and the stated range covers the measured number.
By their numbers in this assay, from the lowest: compounds 2, 4, 1 and 3 (each within the scatter of the next).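

In this assay, the 3-bromophenyl group of compound 4 joins the three earlier rings without separating from any of them: the steps are (a 1.3-fold lower number from compound 3 to compound 4 (0.13 log units; within the scatter)), (a 1.1-fold higher number from compound 2 to compound 4 (0.04 log units; within the scatter)) and (a 1.0-fold lower number from compound 1 to compound 4 (0.01 log units; within the scatter)). The earlier compounds shown here left open whether this place would accept a single bromine in the 3-position, and the step from 4-(tert-butyl)phenyl shows that going from 10 heavy atoms to 7, with the leaving and entering groups both counted as having no hydrogen-bond donors or acceptors, leaves the number within the scatter. Among these four aromatic rings, no swap at this place moves the read-out beyond the scatter, and no compound shown goes against this, but no measurement at hand explains why the number stays put.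

Every ring shown carries only halogen, methoxy or tert-butyl groups, so it remains open whether an amine or a carboxylic acid on the ring, or a longer chain in its place, would shift the number beyond the scatter. All four compounds also share the same core, which leaves the effect of any change elsewhere in the molecule unknown.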